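A few compounds are considered here, and "the series" means these few. Any claim that something is new, unique, unknown or untested is made for them only; others in the source may bear on it.

In a functional assay on HeLa cells (Homo sapiens), read by MTT assay, with a stated time of 72 h (a lower number here means a stronger inhibitor, a higher number a weaker inhibitor), compound 1 `COc1cc(NC(C)CCCNC(=O)NCc2ccncc2)c2ncccc2c1` gives 18000 nM, and that is the only plain number among the two results shown. Compound 2 `COc1cc(NC(C)CCCNC(=O)NC2CCCCC2)c2ncccc2c1` carries cyclohexyl in place of (pyridin-4-yl)methyl on an amide-type nitrogen. In this assay compound 2 reaches only a limit, > 100000 nM. The resulting step, an at least 5.5-fold higher number from compound 1 to compound 2 (0.74 log units; beyond the scatter), is a weakening that runs past (the limit of > 100000 nM in this assay, at which 1 of the 2 values shown sits). Compound 3 `COc1cc(NC(C)CCCNC(=O)NCC2CCCCC2)c2ncccc2c1` differs from compound 1 by cyclohexyl in place of pyridin-4-yl on a saturated chain carbon bound to an amide-type nitrogen. Among the compounds with values here, only the step from compound 1 to compound 2 bears on this change, and it replaced the same pyridin-4-yl ring by a saturated carbon ring, so a weakening of similar kind is expected, though the retained chain carbon leaves the size uncertain. Compound 3 is therefore expected to give about 60000 nM, within 15000 nM to 250000 nM, an expected step of a 3.3-fold higher number from compound 1 to compound 3 (0.52 log units; beyond the scatter), with a fair chance that only a limit is reported.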

Compound 3, half-maximal inhibitory concentration: > 100000 nM
Compound 3: a limit, no number (the forecaster's own chance of this, stated with the estimate: 40%); middle value at least 1.6-fold (0.22 log units) away from the limit.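

In this assay, keeping the saturated chain carbon and changing only pyridin-4-yl to cyclohexyl gives an at least 5.5-fold higher number from compound 1 to compound 3 (0.74 log units; beyond the scatter). Compound 2 had changed the ring and removed that chain carbon together, whereas compound 3 shows that the ring change alone is enough for the loss, with an aromatic ring holding one nitrogen giving way to a ring of carbon only. Compound 2 and compound 3 both end at a limit, so the step between them cannot be read: the limit of > 100000 nM in this assay, at which 2 of the 3 values shown sit.

As far as these compounds go, what remains open is whether the ring nitrogen or the aromatic ring itself matters, and a phenyl group in the same place would separate the two. The role of the chain carbon is also unsettled, and a pyridin-4-yl group carried on a longer chain would test it.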